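Trifluoromethoxy for tert-butyl in two cores

The source may report more compounds than this note shows. Statements on the series, on what has been measured and on what is new or still open speak of the compounds shown alone.

Compound 1 `COC(=O)C1=C(c2ccc(C(C)(C)C)cc2)CCC1` and compound 2 `COC(=O)C1=C(c2ccc(OC(F)(F)F)cc2)CCC1` share one core; compound 3 `COC(=O)[C@@H]1CCCC[C@@H]1c1ccc(C(C)(C)C)cc1` and compound 4 `COC(=O)[C@@H]1CCCC[C@@H]1c1ccc(OC(F)(F)F)cc1` share another; the difference between the two cores is not broken down here. In an assay on COS-1 cells for displacement of a labelled ligand from sodium-dependent dopamine transporter (Homo sapiens) (on this read-out lower numbers stand for stronger inhibition and higher numbers for weaker inhibition), compound 1 gives 302000 nM, compound 2 gives 2650000 nM, and compound 3 gives 766000 nM. The change trifluoromethoxy in place of tert-butyl on an aromatic carbon made the step of an 8.8-fold higher number from compound 1 to compound 2 (0.94 log units; beyond the scatter). Compound 4 carries the same kind of change, (trifluoromethoxy in place of tert-butyl on an aromatic carbon), the place described as para to a large group rather than para to a group of 9 heavy atoms. For compound 4 the step of a 6.5-fold higher number from compound 3 to compound 4 (0.81 log units; beyond the scatter) is expected, resting on the step of an 8.8-fold higher number from compound 1 to compound 2 (0.94 log units; beyond the scatter) seen once only, on a different core. Compound 4 is therefore estimated at 5000000 nM, between 1500000 nM and 15000000 nM.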

Compound 4, inhibition constant: 1180000 nM
Compound 4: middle estimate off by 4.2-fold (0.63 log units), on the high side; measured number below the stated range.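

Trifluoromethoxy in place of tert-butyl gives a 1.5-fold higher number from compound 3 to compound 4 (0.19 log units; within the scatter). The size of the step therefore did not carry from one core to the other: the same change on two cores in this assay, an 8.8-fold higher number (0.94 log units; beyond the scatter) from compound 1 to compound 2 and a 1.5-fold higher number (0.19 log units; within the scatter) from compound 3 to compound 4, 5.7-fold (0.76 log units) apart, beyond the scatter of two such steps

Going by these compounds alone, with only one pair on each core, this shows a core-dependent step for these two pairs alone and does not show which part of the cores accounts for the gap or how the change would behave on a further core.

From the compounds shown here alone, whether an amine, a carboxylic acid or a longer chain on the same aromatic carbon would give steps that also differ between the two cores stays open. The difference between the two cores also stays open, since no pair shown here isolates it.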